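From 4-methoxyphenyl to 3-hydroxyphenyl on the shared core

The source may hold more compounds than are shown below. What is called first, only, known or untested is meant among the compounds shown, and "the series" means these compounds.

Going by the values given here, in a functional assay on HeLa cells (Homo sapiens) for antiproliferative activity, read by MTT assay, with a stated time of 48 h (on this read-out higher numbers stand for weaker inhibition of growth and lower numbers for stronger inhibition of growth), compound 2 `CCOC(=O)N1N=C(c2ccc(OC)cc2)CC1c1cc(OC)c(OC)c(OC)c1` gives 8710 nM, the higher of the two numbers measured so far. Compound 3 `CCOC(=O)N1N=C(c2cccc(O)c2)CC1c1cc(OC)c(OC)c(OC)c1` keeps the shared core but carries 3-hydroxyphenyl in place of 4-methoxyphenyl on a carbon with a double bond to nitrogen. Its closest measured relative is compound 1 `CCOC(=O)N1N=C(c2cccc(OC)c2)CC1c1cc(OC)c(OC)c(OC)c1`, which carries 3-methoxyphenyl and gives 4110 nM. Among the compounds with values here, only one measured step bears on this change: going to 4-methoxyphenyl from 3-methoxyphenyl gave a 2.1-fold higher number from compound 1 to compound 2 (0.33 log units; beyond the scatter), a modest difference. Within the data shown here, no measured compound carries 3-hydroxyphenyl, so the expectation in this assay rests on that single step, taken in reverse, and remains uncertain. The expected change, a modest move to a lower number, is a 2.2-fold lower number from compound 2 to compound 3 (0.34 log units; beyond the scatter). For compound 3 the estimated value is 4000 nM, with an expected range from 1500 nM to 11000 nM.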

Compound 3, concentration for 50% growth inhibition: 3280 nM
Compound 3: the middle estimate sits 1.2-fold (0.09 log units) above what was measured; measured number inside the range.
By their numbers in this assay, from the lowest: compounds 3 and 1 (each within the scatter of the next); then compound 2.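

Replacing 4-methoxyphenyl with 3-hydroxyphenyl gives a 2.7-fold lower number from compound 2 to compound 3 (0.42 log units; beyond the scatter) in this assay, so the number drops with this change, though the step alters both the group on the oxygen and its place on the ring. Taking those apart, hydrogen in place of methyl on the oxygen gives a 1.3-fold lower number from compound 1 to compound 3 (0.10 log units; within the scatter), so the hydroxyl and the methoxy group cannot be told apart here, and the methyl on that oxygen is not required to keep this level of growth inhibition. Nothing in the available evidence explains why these numbers fall as they do.

The compounds shown leave open whether 4-hydroxyphenyl would stay close to 4-methoxyphenyl, which would show if the ring place matters apart from the group. They also leave open whether an amine or a fluorine in place of the hydroxyl on 3-hydroxyphenyl would give a similar number.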